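The source may report more compounds than this note shows. Statements on the series, on what has been measured and on what is new or still open speak of the compounds shown alone.

Of the compounds shown here, two that share one core have been tested in a functional assay on HCT-116 cells (Homo sapiens) for inhibition, read by sulforhodamine B assay, with a stated time of 48 h, tested at 10 uM; on this read-out higher numbers stand for more inhibition at the one concentration tested (going by the name of the read-out) and lower numbers for less inhibition. Compound 1 `O=Cc1ccc(-c2cn3ccnc3c(-c3ccc4ncn(C5CCCCC5)c4c3)n2)cc1` carries a 4-formylphenyl group on that core, and in this assay compound 1 gives 92.6%. Compound 2 `c1cn2cc(-c3ccsc3)nc(-c3ccc4ncn(C5CCCCC5)c4c3)c2n1` carries thiophen-3-yl instead; in this assay compound 2 gives 13.4%. Compound 2 thus stands lowest of the two numbers shown, and its only neighbour, compound 1, sits beyond the scatter above it. For the measured compounds named here, the single measured step, a number 79.2 percentage points lower from compound 1 to compound 2 (beyond the scatter), is large.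

Compound 3 `Brc1ccc(-c2cn3ccnc3c(-c3ccc4ncn(C5CCCCC5)c4c3)n2)cc1` differs from compound 2 as follows: 4-bromophenyl in place of thiophen-3-yl on an aromatic carbon. This change partly reverses the measured step, since a six-membered carbon-only ring returns in place of the five-membered ring; yet the entering group is 4-bromophenyl, not 4-formylphenyl, so that step bears on it only in part. A rise beyond the scatter, toward compound 1, is expected, though its size is uncertain. For compound 3 in this assay the estimate is 60%, with a range from 20% to 95%. The expected step is therefore a number 46.6 percentage points higher from compound 2 to compound 3 (beyond the scatter).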

Compound 3, a percentage reported as inhibition, at one concentration (the size of the read-out at that concentration, not a potency): 31.2%
Beside the measured number, compound 3's estimate is 28.8 percentage points above it, within the range that was stated.
By their numbers in this assay, from the lowest: compound 2; then compound 3; then compound 1.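

At this place on the shared core, a six-membered aromatic ring of carbon only in place of the five-membered sulfur ring gives a modest gain in this assay: a number 17.8 percentage points higher from compound 2 to compound 3 (beyond the scatter). With the phenyl ring kept and only its group changed, bromo in place of formyl gives a large loss, a number 61.4 percentage points lower from compound 1 to compound 3 (beyond the scatter), so the phenyl ring alone does not bring back the high number, and the group it carries makes a large difference in this series. No measurement at hand explains either step.

One formyl compound and one bromo compound cannot show whether the high number is specific to the formyl group or would also appear with other groups on the same phenyl ring, such as a carboxylic acid, an amine or a methoxy group. From the compounds shown here alone, it also remains open whether a formyl group on the thiophen-3-yl ring would raise the number in the same way, which would show whether the effect of that group depends on the ring that carries it.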